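This account rests on a few compounds, and the source may have more. Where it says the series, first, only, none or still open, it means among the compounds named here.

Compound 1 `CNC(=O)[C@@]12C[C@@H]1[C@@H](n1cnc3c(NC)nc(C#Cc4ccccc4F)nc31)[C@H](O)[C@@H]2O` carries a 2-(2-fluorophenyl)ethynyl group on the shared core. Among the measured compounds shown here, in an assay on CHO cells for displacement of a labelled ligand from adenosine receptor A1 (Homo sapiens), read by scintillation counting, with a stated time of 60 min, tested at 10 uM (a higher number here means more inhibition at the concentration tested (going by the name of the read-out), a lower number less inhibition), compound 1 gives 20%, and compound 2 `CNC(=O)[C@@]12C[C@@H]1[C@@H](n1cnc3c(NC)nc(C#Cc4ccccc4OC)nc31)[C@H](O)[C@@H]2O`, with methoxy in place of fluoro on an aromatic carbon, gives 12%; the only measured step, a number 8 percentage points lower from compound 1 to compound 2 (within the scatter), separates the two and stays within the scatter. Compound 3 `CNC(=O)[C@@]12C[C@@H]1[C@@H](n1cnc3c(NC)nc(C#CC4CCCCC4)nc31)[C@H](O)[C@@H]2O` differs from compound 1 by cyclohexyl in place of 2-fluorophenyl on a triple-bonded carbon. No measured step covers a change of this kind; the one step shown is of another sort and small. The expected step is therefore a number 4 percentage points lower from compound 1 to compound 3 (within the scatter), nothing beyond the scatter. Compound 3 is estimated at 16%, within 0% to 38%.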

Compound 3, a percentage reported as inhibition, at one concentration (the size of the read-out at that concentration, not a potency): 15%
Estimate against measurement, compound 3: 1 percentage points above; low and high end bracket the measured number.
By their numbers in this assay, from the lowest: compounds 2, 3 and 1 (each within the scatter of the next).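

On a triple-bonded carbon, cyclohexyl in place of 2-fluorophenyl gives a number 5 percentage points lower from compound 1 to compound 3 (within the scatter), and cyclohexyl in place of 2-methoxyphenyl gives a number 3 percentage points higher from compound 2 to compound 3 (within the scatter). A non-aromatic ring of carbon only at this place therefore reads no differently from either substituted aromatic ring in this assay. Nothing available gives a reason for this reading.

Open, as far as these compounds go, is whether an amine, a carboxylic acid or a longer chain on the same triple-bonded carbon would give a number beyond the scatter of these three compounds.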